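Removing the trifluoromethyl from compound 3

The source may report more compounds than this note shows. Statements on the series, on what has been measured and on what is new or still open speak of the compounds shown alone.

Compound 1 `COc1cccc(CNCCCNc2ccnc3cc(Oc4ccc(Cl)cc4)ccc23)c1O`: 14500 nM
Compound 2 `COc1ccc(Oc2ccc3c(NCCCNCc4cccc(OC)c4O)ccnc3c2)cc1`: 14500 nM
Compound 3 `COc1cccc(CNCCCNc2ccnc3cc(-c4ccc(C(F)(F)F)cc4)ccc23)c1O`: 32000 nM

In a physicochemical assay for solubility, with a stated time of 18 h, at pH 7.4 (a higher number here means a more soluble compound, a lower number a less soluble compound), compound 3 stands highest of the three numbers: a 2.2-fold higher number from compound 1 to compound 3 (0.34 log units; beyond the scatter) and a 2.2-fold higher number from compound 2 to compound 3 (0.34 log units; beyond the scatter) both lie beyond the scatter, while no change at the digits printed from compound 1 to compound 2 (within the scatter) does not. Compound 4 `COc1cccc(CNCCCNc2ccnc3cc(-c4ccccc4)ccc23)c1O` differs from compound 3 by hydrogen in place of trifluoromethyl on an aromatic carbon, which one bond further out reads 4-(trifluoromethyl)phenyl to phenyl. Within the data shown here, the two steps that bear on this position, a 2.2-fold higher number from compound 1 to compound 3 (0.34 log units; beyond the scatter) and a 2.2-fold higher number from compound 2 to compound 3 (0.34 log units; beyond the scatter), each exchanged the whole group there rather than the trifluoromethyl alone, so they give only a loose guide, and no measured step removes a trifluoromethyl by itself. The expected step of a 1.1-fold lower number from compound 3 to compound 4 (0.03 log units; within the scatter) is therefore small, within the scatter. Compound 4 is estimated at 30000 nM, with a range from 13000 nM to 70000 nM.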

Compound 4, solubility: 32000 nM
The estimate for compound 4 lay 1.1-fold (0.03 log units) below the measured number; measured number inside the range.
By their numbers in this assay, from the lowest: compounds 1 and 2 (each within the scatter of the next); then compounds 3 and 4 (each within the scatter of the next).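

In this assay, among these compounds, this is the first step that changes the trifluoromethyl alone, and no change at the digits printed from compound 3 to compound 4 (within the scatter) shows that the number does not depend on that group here. Compared with the 4-methoxyphenoxy and 4-chlorophenoxy groups, the bare phenyl gives a 2.2-fold higher number from compound 2 to compound 4 (0.34 log units; beyond the scatter) and a 2.2-fold higher number from compound 1 to compound 4 (0.34 log units; beyond the scatter), matching the steps already seen with compound 3. No measurement available here explains these numbers. As far as these compounds go, whether an amine or a carboxylic acid in place of that hydrogen would leave the number unchanged remains open.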